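The source may report more compounds than this note shows. Statements on the series, on what has been measured and on what is new or still open speak of the compounds shown alone.

In a functional assay with Mus musculus as the target (on this read-out lower numbers stand for an effect already at smaller amounts and higher numbers for an effect only at larger amounts of compound), compound 1 (`CN(C)CCCn1c(=O)n(C2OC(CO)[C@@H](O)[C@H]2O)c2nc(N)nc(O)c21`) gives 820 uM and compound 2 (`CCOC(=O)Cn1c(=O)n(C2OC(CO)[C@@H](O)[C@H]2O)c2nc(N)nc(O)c21`) gives 630 uM. Among the compounds with values here, these two numbers are all that is known so far, and compound 2 stands level with the only other measured compound, not clearly apart from it. Compound 3 (`CCCCn1c(=O)n(C2OC(CO)[C@@H](O)[C@H]2O)c2nc(N)nc(O)c21`) has not yet been measured. It carries propyl in place of ethoxycarbonyl on a saturated chain carbon bound to an aromatic nitrogen. Cut one bond further out, the same difference reads (ethoxycarbonyl)methyl to butyl.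

Within the data shown here, one measured step bears on this change, and it concerns the same place: ethoxycarbonyl in place of 2-(dimethylamino)ethyl gave a 1.3-fold lower number from compound 1 to compound 2 (0.11 log units; within the scatter). A single step is thin ground, and neither measured compound carries propyl there. Even so, no step beyond the scatter is expected in this assay, and no direction can be favoured. The estimate therefore amounts to an expected 1.1-fold lower number from compound 2 to compound 3 (0.02 log units; within the scatter). For compound 3 the expected value is 600 uM, with an estimated range from 250 uM to 1400 uM.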

Compound 3, concentration for half-maximal effect: 100 uM
The estimate for compound 3 lay 6.0-fold (0.78 log units) above the measured number; the measured number lies below the stated range.
By their numbers in this assay, from the lowest: compound 3; then compounds 2 and 1 (each within the scatter of the next).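

In this assay, within the data shown here, the group on a saturated chain carbon bound to an aromatic nitrogen proves able to move the read-out: propyl in place of ethoxycarbonyl gave a 6.3-fold lower number from compound 2 to compound 3 (0.80 log units; beyond the scatter), whereas the one earlier step at this place had stayed within the scatter. Methyl in place of dimethylamino on a saturated chain carbon, three bonds along the chain from an aromatic nitrogen, gave an 8.2-fold lower number from compound 1 to compound 3 (0.91 log units; beyond the scatter), so the butyl chain of compound 3 stands clearly apart from the chains of both compound 1 and compound 2, and these two remain level with each other. Nothing measured here accounts for this separation, and the numbers show only that it exists.

The compounds shown leave open whether the trend continues with a longer chain such as hexyl, or reverses with a shorter one such as ethyl or methyl. They also leave open how a chain ending in a hydroxyl group or a carboxylic acid would compare with the butyl chain of compound 3, and whether a ring at the same place would keep the lower number.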